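The source may report more compounds than this note shows. Statements on the series, on what has been measured and on what is new or still open speak of the compounds shown alone.

Three compounds have been measured in a functional assay on the whole organism (strain Sprague-Dawley) for inhibition, with Rattus norvegicus as the target, with a stated time of 10 min; a higher number here means that more compound is needed for the effect, a lower number that less compound is needed:

compound 1 `CCCOc1ccccc1-c1ncc(C(=O)O)c(=O)[nH]1` gives 0.9 mg/kg
compound 2 `CC(C)COc1ccccc1-c1ncc(C(=O)O)c(=O)[nH]1` gives 0.5 mg/kg
compound 3 `CCOc1ccc(OC)cc1-c1ncc(C(=O)O)c(=O)[nH]1` gives 0.2 mg/kg

Compound 1 and compound 2 differ in one place, by methyl in place of hydrogen on a saturated chain carbon bound to two saturated chain carbons. This change made a 1.8-fold lower number from compound 1 to compound 2 (0.26 log units; within the scatter). Compound 3 gives the lowest number of the three, and its gaps to compound 2 and to compound 1 both lie beyond the scatter, so it is the most potent of the three measured compounds. The difference between the core of compound 1 and the core of compound 3 is not broken down here.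

Compound 4 `CCCOc1ccc(OC)cc1-c1ncc(C(=O)O)c(=O)[nH]1` is not yet measured. It differs from compound 3 by methyl in place of hydrogen on a saturated chain carbon, two bonds along the chain from an oxygen on an aromatic ring. Within the data shown here, this is the same kind of change as the one from compound 1 to compound 2, but not the same: there the entering methyl sat on a saturated chain carbon bound to two saturated chain carbons, here it sits on a saturated chain carbon, two bonds along the chain from an oxygen on an aromatic ring.

Among the measured compounds shown here, because the one measured example of this kind of change, a 1.8-fold lower number from compound 1 to compound 2 (0.26 log units; within the scatter), stayed within the scatter, compound 4 is expected to land close to compound 3, with the step of a 1.3-fold lower number from compound 3 to compound 4 (0.10 log units; within the scatter) expected to be small. Compound 4 is therefore estimated at 0.16 mg/kg, with a likely range from 0.06 mg/kg to 0.45 mg/kg, in this assay.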

Compound 4, dose for 50% inhibition: 0.3 mg/kg
Compound 4: the middle estimate sits 1.9-fold (0.27 log units) below what was measured; low and high end bracket the measured number.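

In this assay, the step from ethoxy to propoxy on the methoxy-bearing core gave a 1.5-fold higher number from compound 3 to compound 4 (0.18 log units; within the scatter), while methoxy in place of hydrogen on an aromatic carbon gave a 3.0-fold lower number from compound 1 to compound 4 (0.48 log units; beyond the scatter), a modest step that lies beyond the scatter. Among these compounds, each methyl step taken alone stays within the scatter, yet the two differ by more than such a pair of steps would be expected to, so this change did not carry over as one fixed step from one core to the other: the same change on two cores in this assay, a 1.8-fold lower number (0.26 log units; within the scatter) from compound 1 to compound 2 and a 1.5-fold higher number (0.18 log units; within the scatter) from compound 3 to compound 4, 2.7-fold (0.43 log units) apart, beyond the scatter of two such steps This does not show what lies behind the gap, for only one pair stands on each core and the methyl enters at a different place in each, so the core and the place of the methyl cannot be told apart.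

The methoxy step also rests on a single pair, which leaves open whether it would be of like size with other chains on the oxygen. Also open, from the compounds shown here alone, is how a longer chain, a fluorine on the aromatic ring or an amide in place of the carboxylic acid would read in this assay.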